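Double-bond geometry in the series: compound 3 to compound 4

The source may report more compounds than this note shows. Statements on the series, on what has been measured and on what is new or still open speak of the compounds shown alone.

Measured so far in an ADME assay on NIH3T3 cells (Mus musculus) for cytotoxicity, read by neutral red uptake, with a stated time of 48 h; on this read-out higher numbers stand for lower toxicity in this test and lower numbers for higher toxicity in this test (half-maximal toxic concentration):
compound 1 `CCCCCCCC/C=C\c1c(C)nc(C)c(/C=C\CCCCCCCC)c1C` gives "not determined" (no result reported)
compound 2 `CCCCCCCC/C=C\c1c(C)c(/C=C\CCCCCCCC)c2[n+](c1C)CCC2` gives 22.7 uM
compound 3 `CCCCCCCC/C=C/c1c(C)c(/C=C/CCCCCCCC)c2[n+](c1C)CCC2` gives 2.5 uM

Compound 3 holds the lower of the two numbers available, and compound 1 offers no number for comparison. The next compound to be tested is compound 4 `CCCCCCCC/C=C\c1c(C)c(/C=C/CCCCCCCC)c(C)[n+]2c1CCC2` and the change from the previous one is this: the two compounds have the same atoms and bonds and differ only in configuration as drawn: 1 of 2 stereo elements differ; a double bond is drawn E in compound 3 and Z in compound 4 with nothing leaving or entering.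

Among the measured compounds shown here, only one measured step bears on this change, namely a 9.1-fold lower number from compound 2 to compound 3 (0.96 log units; beyond the scatter) in which both double bonds differ. That gap lies beyond the scatter and can be traced to the configuration alone (the fact that compounds 2 and 3 differ only in the configuration as drawn). For the measured compounds named here, compound 4 takes back only one of the two changes in a 9.1-fold lower number from compound 2 to compound 3 (0.96 log units; beyond the scatter) and a partial return towards the higher number is therefore expected. The data do not show whether the two double bonds count equally, so an even split is an assumption. The expected value for compound 4 is 7.5 uM (estimated range 3 uM to 20 uM). This estimate means a 3.0-fold higher number from compound 3 to compound 4 (0.48 log units; beyond the scatter) in this assay as the expected step.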

Compound 4, half-maximal toxic concentration: 3.2 uM
For compound 4 the middle estimate is 2.3-fold (0.37 log units) above the measured one; the measured number falls inside the stated range.
By their numbers in this assay, from the lowest: compounds 3 and 4 (each within the scatter of the next); then compound 2.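

In this assay, reversing a single double bond from E to Z gives a 1.3-fold higher number from compound 3 to compound 4 (0.11 log units; within the scatter), so the mixed geometry of compound 4 cannot be told apart from the all-E geometry of compound 3. The other new step is a 7.1-fold lower number from compound 2 to compound 4 (0.85 log units; beyond the scatter), so a single E double bond is enough here to separate a compound from the all-Z form, and this separation rests on configuration alone: the fact that compounds 2 and 4 differ only in the configuration as drawn. The earlier pair could show only both double bonds changing together, whereas these steps show that, for the double bond changed here, the return to Z does not bring back the higher number of the all-Z form.

As far as these compounds go, the other mixed form, with the Z and E geometries swapped between the two double bonds, stands outside these compounds, so it remains open whether either double bond alone would give the same result. Also open, from the compounds shown here alone, is whether the link between geometry and the number in this assay would persist with fully saturated alkyl chains or with a terminal carboxylic acid on each chain.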